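Swapping 3-chlorophenyl for naphthalen-2-yl on a shared core

This account rests on a few compounds, and the source may have more. Where it says the series, first, only, none or still open, it means among the compounds named here.

Measured so far in a functional assay on HEL cells (Homo sapiens) for cytotoxicity; on this read-out higher numbers stand for lower toxicity in this test and lower numbers for higher toxicity in this test:
compound 1 `CO[C@@H]1[C@@H](OC)[C@H](c2ccccc2)O[C@@H]2CO[C@@H](C3CCCCC3)O[C@@H]12` reads 28 ug/mL
compound 2 `CO[C@@H]1[C@@H](OC)[C@H](c2ccccc2)O[C@@H]2CO[C@@H](c3cccc(Cl)c3)O[C@@H]12` reads "not determined" (no result reported)

Compound 2 has no place on this scale. No number stands for it, so it cannot be ranked against compound 1 as more or less toxic. Compound 3 `CO[C@@H]1[C@@H](OC)[C@H](c2ccccc2)O[C@@H]2CO[C@@H](c3ccc4ccccc4c3)O[C@@H]12` keeps the shared core and alters a single group. The step is naphthalen-2-yl in place of 3-chlorophenyl on a saturated ring carbon, which puts naphthalen-2-yl in place of 3-chlorophenyl on a saturated ring carbon, between two ring oxygen atoms.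

With no starting number for compound 2, the size of this step in this assay cannot be read from its own starting point. For the measured compounds named here, the only anchor is compound 1 at 28 ug/mL, and one value shows no trend. The expectation is therefore no shift beyond the usual scatter from that single number, in either direction, with a wide margin of doubt. For compound 3 the estimated value is 30 ug/mL, with an expected range from 9 ug/mL to 100 ug/mL.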

Compound 3, half-maximal cytotoxic concentration: > 50 ug/mL
Compound 3: a limit, no number; the forecaster's own chance of this, stated with the estimate: 30%; middle value at least 1.6-fold (0.22 log units) from the limit.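

Compound 3 gives a limit rather than a number in this assay, and it is the only compound shown that does so: the limit of > 50 ug/mL in this assay, at which 1 of the 3 values shown sits. For the compounds shown here, with naphthalen-2-yl in place of cyclohexyl on a saturated ring carbon, between two ring oxygen atoms, the reading shows an at least 1.7-fold higher number from compound 1 to compound 3 (0.25 log units; that floor lies within the scatter), so the first aromatic group with a result at this position cannot yet be separated with confidence from the saturated ring of compound 1. Compound 2 has no result, and the step from compound 2 to compound 3 cannot be read, so nothing can be said about exchanging 3-chlorophenyl for naphthalen-2-yl in this test.

As far as these compounds go, how far compound 3 really lies from compound 1 stays open, as a limit gives only one side of the gap, and a single aromatic group cannot show whether aromatic groups in general behave alike here. Also open, from the compounds shown here alone, is how this same carbon would read in this assay when carrying an amine, a carboxylic acid or a longer alkyl chain.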